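Swapping hydroxy for chloro on the aryl ketone

The source may hold more compounds than are shown below. What is called first, only, known or untested is meant among the compounds shown, and "the series" means these compounds.

Measured so far:
compound 1 `COc1ccc(C(=O)/C=C/c2cc3ccccc3[nH]c2=O)cc1` — 88700 nM
compound 2 `O=C(/C=C/c1cc2ccccc2[nH]c1=O)c1ccc(O)cc1` — 16800 nM

In a functional assay on MCF7 cells (Homo sapiens) for cytotoxicity, read by sulforhodamine B assay, with a stated time of 24 h (on this read-out higher numbers stand for weaker inhibition of growth and lower numbers for stronger inhibition of growth), compound 2 gives the lowest of the two numbers; its nearest neighbour is compound 1, and the step of a 5.3-fold lower number from compound 1 to compound 2 (0.72 log units; beyond the scatter) lies beyond the scatter. Compound 3 `O=C(/C=C/c1cc2ccccc2[nH]c1=O)c1ccc(Cl)cc1` differs from compound 2 by chloro in place of hydroxy on an aromatic carbon. Within the data shown here, no measured step concerns chloro, so the only guide is that removing the methyl from the oxygen lowered the number. Chloro offers neither the donor nor the acceptor of hydroxy, so compound 3 is expected to fall between compounds 1 and 2, a step of a 2.4-fold higher number from compound 2 to compound 3 (0.38 log units; beyond the scatter). The estimate for compound 3 is 40000 nM, within 10000 nM to 150000 nM.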

Compound 3, concentration for total growth inhibition: > 100000 nM
Compound 3 ended at the assay's limit; the forecaster's own chance of this, stated with the estimate: 10%; middle value at least 2.5-fold (0.39 log units) from the limit.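

In this assay compound 3 gives > 100000 nM, which is a limit of the assay and not a number. Chloro in place of hydroxy brings an at least 5.9-fold higher number from compound 2 to compound 3 (0.77 log units; beyond the scatter), so the lower number of compound 2 now holds against two different groups at this position, not only methoxy. Chloro in place of methoxy brings an at least 1.1-fold higher number from compound 1 to compound 3 (0.05 log units; that floor lies within the scatter), so these two groups cannot be put in order. The compounds shown leave open whether an amine or a carboxylic acid at this place would match hydroxy.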